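Thiophene series: carboxy removal on the naphthyl-bearing core

The source may hold more compounds than are shown below. What is called first, only, known or untested is meant among the compounds shown, and "the series" means these compounds.

Measured so far:
compound 1 `COc1ccc(-c2sc(C(=O)O)cc2-c2cc(OC)c(OC)c(OC)c2)cc1`: 7800 nM
compound 2 `COc1cc(-c2cc(C(=O)O)sc2-c2ccc3ccccc3c2)cc(OC)c1OC`: 380 nM
compound 3 `COc1ccc(-c2sccc2-c2cc(OC)c(OC)c(OC)c2)cc1`: 5470 nM

All numbers come from a functional assay on SGC-7901 cells (Homo sapiens) for antiproliferative activity, read by MTT assay, with a stated time of 72 h; a higher number here means a weaker inhibitor, a lower number a stronger inhibitor. Compound 2 gives the lowest number of the three, and its steps to compound 3 and to compound 1 both lie beyond the scatter. The cores of compound 1 and compound 2 differ by naphthalen-2-yl in place of 4-methoxyphenyl on an aromatic carbon, which made a 21-fold lower number from compound 1 to compound 2 (1.31 log units; beyond the scatter). The change hydrogen in place of carboxy on an aromatic carbon made a 1.4-fold lower number from compound 1 to compound 3 (0.15 log units; within the scatter).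

Compound 4 `COc1cc(-c2ccsc2-c2ccc3ccccc3c2)cc(OC)c1OC` is unmeasured and differs from compound 2 by hydrogen in place of carboxy on an aromatic carbon. This is the same kind of change as that from compound 1 to compound 3, though the surroundings differ: in compound 1 the place is two ring bonds from the ring atom that bears a 4-methoxyphenyl group, in compound 2 two ring bonds from the ring atom that bears a naphthalen-2-yl group. Since a 1.4-fold lower number from compound 1 to compound 3 (0.15 log units; within the scatter) lay within the scatter, compound 4 is expected to show a 1.3-fold lower number from compound 2 to compound 4 (0.10 log units; within the scatter). Compound 4 is estimated at 300 nM, within 120 nM to 900 nM.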

Compound 4, half-maximal inhibitory concentration: 5890 nM
Estimate against measurement, compound 4: 20-fold (1.29 log units) below; measured number outside the range, above it.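

On the core of compound 2, hydrogen in place of carboxy gave, in this assay, a 16-fold higher number from compound 2 to compound 4 (1.19 log units; beyond the scatter), so the carboxy group counts on this core. The change therefore does not carry from one core to the other with the same result: the same change on two cores in this assay, a 1.4-fold lower number (0.15 log units; within the scatter) from compound 1 to compound 3 and a 16-fold higher number (1.19 log units; beyond the scatter) from compound 2 to compound 4, 22-fold (1.34 log units) apart, beyond the scatter of two such steps

This is a single pair of cores, and it shows neither why they part nor how the change would behave on any third core.

The compounds shown leave open whether a methyl ester or a primary amide in place of carboxy would hold the number of compound 2. Also open, going by these compounds, is what the change does on a core bearing phenyl or 4-chlorophenyl in place of naphthalen-2-yl.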